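Adding a (4-Fluorobenzyl)sulfanyl Group to Compound 1

The source may report more compounds than this note shows. Statements on the series, on what has been measured and on what is new or still open speak of the compounds shown alone.

In a functional assay on MCF7 cells (Homo sapiens) for inhibition, read by MTT assay, with a stated time of 72 h (on this read-out lower numbers stand for stronger inhibition and higher numbers for weaker inhibition), compound 1 `Cc1cc(Nc2cc(-c3ccccc3)[nH]n2)n2ncnc2n1` gives > 50000 nM, which is a limit of the assay and not a number.
In this assay compound 2 `Cc1cc(Nc2cc(-c3ccc(Cl)cc3)[nH]n2)n2nc(SCc3ccc(Br)cc3)nc2n1` gives 3620 nM.

Compound 1 stands at the limit of > 50000 nM in this assay, at which 1 of the 2 values shown sits. Within the data shown here, compound 2 is the only one of the two with a numerical value, and it carries a benzylsulfanyl group on the shared core together with a chlorine on its phenyl ring, so compound 1 and compound 2 differ in two places and no single step connects them. Compound 3 `Cc1cc(Nc2cc(-c3ccccc3)[nH]n2)n2nc(SCc3ccc(F)cc3)nc2n1` keeps the plain phenyl ring of compound 1 and adds only the sulfur-linked group: (4-fluorobenzyl)sulfanyl in place of hydrogen on an aromatic carbon.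

Since compound 1 only reaches the limit, the step to compound 3 in this assay cannot be read from a measured pair. The expectation is a clear gain in inhibition, beyond the usual scatter, because compound 2, which also carries a benzylsulfanyl group, gives 3620 nM. Compound 3 is estimated at 8000 nM, with a likely range from 2500 nM to 30000 nM, which would mean an expected step of an at least 6.2-fold lower number from compound 1 to compound 3 (0.79 log units; beyond the scatter).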

Compound 3, half-maximal inhibitory concentration: 4020 nM
The estimate for compound 3 lay 2.0-fold (0.30 log units) above the measured number; measured number inside the range.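

In this assay, placing (4-fluorobenzyl)sulfanyl in place of hydrogen on the aromatic carbon gives an at least 12-fold lower number from compound 1 to compound 3 (1.09 log units; beyond the scatter), the only step shown at this position that connects two compounds differing in one place. For compound 1, the value > 50000 nM is a limit of the assay and not a number, so the step gives only a bound on the size of the change: the limit of > 50000 nM in this assay, at which 1 of the 3 values shown sits. The plain phenyl ring of compound 1 is kept in compound 3, which gives 4020 nM, so this change reaches a numerical value without a chlorine on that ring.

Among these compounds, the single change adds the sulfur, the benzyl ring and the fluorine together, and compound 2 differs from compound 3 in more than one place, which leaves open which part of the new group accounts for the step. Also open, going by these compounds, is how a smaller methylsulfanyl group, an unsubstituted benzylsulfanyl group or an amine on the same aromatic carbon would read in this assay.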